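Bromo substitution on two cores in an antiproliferative series

The source may hold more compounds than are shown below. What is called first, only, known or untested is meant among the compounds shown, and "the series" means these compounds.

Measured compounds, with values in a functional assay on MGC-803 cells (Homo sapiens) for antiproliferative activity, read by MTT assay, with a stated time of 72 h; a higher number here means a weaker inhibitor, a lower number a stronger inhibitor:
compound 1, `O=C(COc1ccc(C(=O)/C=C/c2cccc(Br)c2)cc1)N[C@H]1CCOC1=O`: 11900 nM
compound 2, `O=C(CNc1ccccc1)N[C@H]1CCOC1=O`: only a limit, > 64000 nM
compound 3, `O=C(COc1ccc(C(=O)/C=C/c2ccccc2)cc1)N[C@H]1CCOC1=O`: only a limit, > 64000 nM

Compound 2 is reported in this assay only as a limit, > 64000 nM. Compound 3 is likewise reported only as a limit, > 64000 nM. The limit is the same in both cases, (the limit of > 64000 nM in this assay, at which 2 of the 3 values shown sit), so only compound 1 carries a number.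

Among the compounds with values here, the one measured step is an at least 5.3-fold lower number from compound 3 to compound 1 (0.73 log units; beyond the scatter), the change being (bromo in place of hydrogen on an aromatic carbon). Compound 4, `O=C(CNc1ccc(Br)cc1)N[C@H]1CCOC1=O`, is not yet measured; it differs from compound 2 by bromo in place of hydrogen on an aromatic carbon. Within the data shown here, this is the same kind of change as the one from compound 3 to compound 1, but the place is not identical: the bromo is para to a large group in compound 4 and meta to a large group in compound 1. The difference between the core of compound 2 and the core of compound 3 is not broken down here.

For compound 4 in this assay a step of an at least 1.6-fold lower number from compound 2 to compound 4 (0.20 log units; that floor lies within the scatter) is expected, resting on the size of an at least 5.3-fold lower number from compound 3 to compound 1 (0.73 log units; beyond the scatter) applied to a starting point that is itself only a limit. The estimate for compound 4 is 40000 nM, expected between 10000 nM and 128000 nM.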

Compound 4, half-maximal inhibitory concentration: > 64000 nM
Compound 4: only a limit was reported (the forecaster's own chance of this, stated with the estimate: 55%); at least 1.6-fold (0.20 log units) between middle value and limit.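

Compound 2 and compound 4 are both reported only as limits, so no step can be read between them: the limit of > 64000 nM in this assay, at which 3 of the 4 values shown sit.

The compounds shown leave open whether bromo in place of hydrogen on an aromatic carbon changes the number at all on the core of compound 2, and whether core or place separates this pair from compound 3 and compound 1.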